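Notes on compound 4, methyl in place of diethylamino

A few compounds are considered here, and "the series" means these few. Any claim that something is new, unique, unknown or untested is made for them only; others in the source may bear on it.

Measured so far in a functional assay on T47D cells (Homo sapiens) for cytotoxicity, read by MTT assay, with a stated time of 2 days; a lower number here means a stronger inhibitor, a higher number a weaker inhibitor:
compound 1 `O=c1[nH]c(-c2cccc3ccccc23)nc2ccc(N3CCCCC3)cc12` gives > 50000 nM, a limit of the assay.
compound 2 `CCN(CC)c1ccc2nc(-c3cccc4ccccc34)[nH]c(=O)c2c1` gives 2690 nM.
compound 3 `Cc1cccc(-c2nc3cc(C)ccc3c(=O)[nH]2)c1` gives > 50000 nM, a limit of the assay.

Going by the values given here, compound 2 holds the only numerical value in this assay; the other two entries are limits. Among the compounds with values here, the single measured step, an at least 18-fold lower number from compound 1 to compound 2 (1.26 log units; beyond the scatter), is the sole guide for size. Compound 4 `Cc1ccc2nc(-c3cccc4ccccc34)[nH]c(=O)c2c1` differs from compound 2 by methyl in place of diethylamino on an aromatic carbon. Within the data shown here, no measured step matches this change; the measured step shows that swapping the group on that aromatic carbon can move the number well beyond the scatter, and the limit of > 50000 nM in this assay, at which 2 of the 3 values shown sit, shows where most of the series sits. A higher number is therefore expected, and compound 4 is estimated at 20000 nM (range 4000 nM to 60000 nM), an expected step of a 7.4-fold higher number from compound 2 to compound 4 (0.87 log units; beyond the scatter), with a real chance of another limit.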

Compound 4, half-maximal inhibitory concentration: > 50000 nM
Compound 4 ended at the assay's limit (the forecaster's own chance of this, stated with the estimate: 45%); middle value at least 2.5-fold (0.39 log units) from the limit.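

In this assay, the measurable number at this aromatic carbon depends on keeping diethylamino, since methyl in its place gives an at least 18-fold higher number from compound 2 to compound 4 (1.26 log units; beyond the scatter). Both methyl and piperidin-1-yl at this carbon now leave the series at the limit, so compound 2 stands alone with a number: the limit of > 50000 nM in this assay, at which 3 of the 4 values shown sit. The step between compound 1 and compound 4 cannot be read.

Still open, going by these compounds, is how narrow the requirement at this carbon is: dimethylamino, dipropylamino or an open-chain ether on the same carbon could show whether any group other than diethylamino gives a number.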